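The compounds below may be only part of what the source reports. "The series", "measured", "known", "first", "only" and "open" are said of these compounds alone.

Three esters of a shared core have been measured in a functional assay on HeLa cells (Homo sapiens) for cytotoxicity, read by MTT assay; a higher number here means a weaker inhibitor, a lower number a stronger inhibitor. Compound 1, `CCCC(O)CC(=O)O[C@H](CC=C(C)C)C1=CC(=O)c2c(O)ccc(O)c2C1=O`, gives 59300 nM. Compound 2, `CCCC(C)(O)CC(=O)O[C@H](CC=C(C)C)C1=CC(=O)c2c(O)ccc(O)c2C1=O`, gives 72000 nM, and compound 3, `CCCCC(C)(O)CC(=O)O[C@H](CC=C(C)C)C1=CC(=O)c2c(O)ccc(O)c2C1=O`, gives 60600 nM. Compound 3 stands second highest of the three numbers; its nearest neighbour is compound 1 and its furthest is compound 2, and both gaps lie within the scatter. The steps between these compounds are all small: a 1.2-fold higher number from compound 1 to compound 2 (0.08 log units; within the scatter), a 1.0-fold higher number from compound 1 to compound 3 (0.01 log units; within the scatter) and a 1.2-fold lower number from compound 2 to compound 3 (0.07 log units; within the scatter).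

Compound 4, `CC(C)=CC[C@@H](OC(=O)CC(O)c1ccccc1)C1=CC(=O)c2c(O)ccc(O)c2C1=O`, differs from compound 3 in one place: hydroxy(phenyl)methyl in place of 1-hydroxy-1-methylpentyl on a saturated chain carbon bound to a carbonyl carbon. Among the measured compounds shown here, none of the measured steps exchanges a saturated chain for an aromatic ring, so no measured step bears directly on this change; the measured steps only show that a methyl added to the side chain, as from compound 1 to compound 2 and from compound 2 to compound 3, left this assay unchanged beyond the scatter. Bringing in a six-membered aromatic ring is a larger change than any of these, but with no measured step of that kind the expectation is for no step beyond the scatter. Compound 4 is therefore expected to give 55000 nM, with a range from 25000 nM to 120000 nM, an expected step of a 1.1-fold lower number from compound 3 to compound 4 (0.04 log units; within the scatter).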

Compound 4, half-maximal inhibitory concentration: 44500 nM
Estimate against measurement, compound 4: 1.2-fold (0.09 log units) above; the range from low to high includes it.
By their numbers in this assay, from the lowest: compounds 4, 1, 3 and 2 (each within the scatter of the next).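

The position on a saturated chain carbon bound to a carbonyl carbon holds an aromatic ring as well as a saturated chain with no step beyond the scatter in this assay (hydroxy(phenyl)methyl in place of 1-hydroxy-1-methylpentyl: a 1.4-fold lower number from compound 3 to compound 4 (0.13 log units; within the scatter); hydroxy(phenyl)methyl in place of 1-hydroxy-1-methylbutyl: a 1.6-fold lower number from compound 2 to compound 4 (0.21 log units; within the scatter); phenyl in place of propyl: a 1.3-fold lower number from compound 1 to compound 4 (0.12 log units; within the scatter)). The earlier steps shown here had changed only saturated chains, whereas these three bring in a six-membered aromatic ring of carbon only, and the four compounds still do not separate from one another. Nothing available here gives a reason why the number holds across this exchange.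

Still open, on these data alone, is whether a substituted ring, such as a chlorophenyl or methoxyphenyl group, or a pyridine ring would take the number beyond the scatter. As far as these compounds go, all four side chains also carry a hydroxy group, so it remains open what an amine or a carboxylic acid in its place would do in this assay (the shared core staying the same).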